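From fluoro to nitro on a shared core

The source may hold more compounds than are shown below. What is called first, only, known or untested is meant among the compounds shown, and "the series" means these compounds.

- compound 1 (`CCc1ccc(NC(=S)N/N=C\c2ccnc3ccccc23)cc1`) gives 35700 nM
- compound 2 (`Fc1ccc(NC(=S)N/N=C\c2ccnc3ccccc23)cc1`) gives 45900 nM

Both values come from an ADME assay on RAW264.7 cells (Mus musculus) for cytotoxicity, read by MTT assay, with a stated time of 48 h (a higher number here means that more compound is tolerated, a lower number that less compound is tolerated), and they lie within the usual scatter of each other, so compound 2 (45900 nM) cannot be separated from compound 1 (35700 nM) on these numbers. The next compound, compound 3 (`O=[N+]([O-])c1ccc(NC(=S)N/N=C\c2ccnc3ccccc23)cc1`), carries nitro in place of fluoro on an aromatic carbon, para to a large group (nitro in place of fluoro on an aromatic carbon). Among the measured compounds shown here, only one measured step bears on this change. It alters the same aromatic carbon, with fluoro in place of ethyl, and it stayed within the scatter (a 1.3-fold higher number from compound 1 to compound 2 (0.11 log units; within the scatter)). For the measured compounds named here, no compound with nitro has yet been measured, so that single small step is weak guidance and the range has to stay wide. No step beyond the scatter is therefore expected in this assay, and no clear direction can be assigned. The expected step is small (a 1.2-fold lower number from compound 2 to compound 3 (0.08 log units; within the scatter)). For compound 3 the estimated value is 38000 nM (expected range 13000 nM to 85000 nM).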

Compound 3, half-maximal cytotoxic concentration: 82500 nM
Beside the measured number, compound 3's estimate is 2.2-fold (0.34 log units) below it; the range from low to high includes it.
By their numbers in this assay, from the lowest: compounds 1, 2 and 3 (each within the scatter of the next, the first and the last beyond it).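

In this assay, the aromatic carbon para to a large group now shows its first separation between compounds: nitro in place of ethyl gives a 2.3-fold higher number from compound 1 to compound 3 (0.36 log units; beyond the scatter), a modest step and the only one of the three that passes the scatter. Nitro in place of fluoro gives a 1.8-fold higher number from compound 2 to compound 3 (0.25 log units; within the scatter), which stays within it, so on these numbers nitro is set apart from ethyl but not from fluoro, and this position can be said to affect how much compound the cells tolerate, though only slightly. Nothing available explains the separation between the ethyl and nitro compounds.

The compounds shown leave open whether a group of a different kind on this same carbon, such as an amine, a carboxylic acid or a longer chain, would move the number further or stay within the scatter of these three. They also leave open whether nitro would give a similar step on another carbon of the shared core, since all three changes fall at a single place.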